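Removing a Methoxy Group Alongside an Amino Group

The compounds below may be only part of what the source reports. "The series", "measured", "known", "first", "only" and "open" are said of these compounds alone.

Compound 1 `COc1ccc([C@@H]2[C@H](Oc3ccccc3)C(=O)N2c2cc(OC)c(OC)c(OC)c2)cc1`, compound 2 `COc1ccc([C@@H]2[C@H](Oc3ccccc3)C(=O)N2c2cc(OC)c(OC)c(OC)c2)cc1OC` and compound 3 `COc1ccc([C@@H]2[C@H](Oc3ccccc3)C(=O)N2c2cc(OC)c(OC)c(OC)c2)cc1N` share one core and were tested in a functional assay on MCF7 cells (Homo sapiens) for antiproliferative activity, read by MTT assay, with stated times of 24 h and 72 h; on this read-out higher numbers stand for weaker inhibition and lower numbers for stronger inhibition. Compound 1 gives 35000 nM, compound 2 gives 26000 nM, and compound 3 gives 12200 nM, the lowest of the three. The cores of compound 2 and compound 3 differ by amino in place of methoxy on an aromatic carbon, with a 2.1-fold lower number from compound 2 to compound 3 (0.33 log units; beyond the scatter). Separately, hydrogen in place of methoxy on an aromatic carbon gave a 1.3-fold higher number from compound 2 to compound 1 (0.13 log units; within the scatter). Compound 4 `COc1cc(N2C(=O)[C@@H](Oc3ccccc3)[C@H]2c2cccc(N)c2)cc(OC)c1OC` differs from compound 3 by hydrogen in place of methoxy on an aromatic carbon, the same kind of change, though here the place is ortho to an amino group and para to a large group rather than ortho to a methoxy group and meta to a large group. Because a 1.3-fold higher number from compound 2 to compound 1 (0.13 log units; within the scatter) stayed within the scatter, a step of similar size is expected, and the step from compound 3 to compound 4 is estimated as a 1.1-fold higher number from compound 3 to compound 4 (0.06 log units; within the scatter). Compound 4 is therefore expected to give about 14000 nM, between 6000 nM and 35000 nM.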

Compound 4, half-maximal inhibitory concentration: 17000 nM
Beside the measured number, compound 4's estimate is 1.2-fold (0.08 log units) below it; low and high end bracket the measured number.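

In this assay, the step of a 1.4-fold higher number from compound 3 to compound 4 (0.14 log units; within the scatter) matches the earlier step on the core without the amino group, so hydrogen in place of methoxy carried over between these two cores: the same change on two cores in this assay, a 1.3-fold higher number (0.13 log units; within the scatter) from compound 2 to compound 1 and a 1.4-fold higher number (0.14 log units; within the scatter) from compound 3 to compound 4, 1.0-fold (0.01 log units) apart, within the scatter of two such steps. Exchanging the whole aromatic group gave a 1.5-fold lower number from compound 2 to compound 4 (0.18 log units; within the scatter) and a 2.1-fold lower number from compound 1 to compound 4 (0.31 log units; beyond the scatter), and only the second of these lies beyond the scatter. The agreement rests on just two cores and on two steps that both stay within the scatter, so it does not show that the change would stay this small on any other core in the series.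

The compounds shown leave open whether a hydroxy group or a fluorine atom in place of the methoxy group would give a similar step. They also leave open whether an acetamido group could stand in for the amino group.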